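A few compounds are considered here, and "the series" means these few. Any claim that something is new, unique, unknown or untested is made for them only; others in the source may bear on it.

Measured values in an ADME assay on BJ cells (Homo sapiens) for antiproliferative activity, with a stated time of 72 h (on this read-out lower numbers stand for an effect already at smaller amounts and higher numbers for an effect only at larger amounts of compound), follow

compound 1 `COc1ccc(-c2cc(=O)c3c(OC)cc(OC)cc3n2C)cc1` gives 68000 nM
compound 2 `COC(=O)c1cc(=O)c2c(OC)cc(OC)cc2[nH]1` gives > 34400 nM

Compound 2 stands at a limit of the assay and not at a number, > 34400 nM. The two values shown include (the limit of > 34400 nM in this assay, at which 1 of the 2 values shown sits), so the position of compound 2 is only bounded on one side.

The next compound is compound 3 `COC(=O)c1cc(=O)c2c(OC)cc(OC)cc2n1C`, where methyl takes the place of hydrogen on an aromatic nitrogen: methyl in place of hydrogen on an aromatic nitrogen. Among the compounds with values here, no pair of measured compounds isolates this change, so any expectation for it rests on little. Compound 1 also carries a methyl on its aromatic nitrogen and gives 68000 nM, which offers no reason to expect a large gain in this assay from the methyl. A small step with no firm direction is expected, probably not beyond the usual scatter, and compound 3 may also read only as a limit. The estimated change is a step that the limit leaves unreadable from compound 2 to compound 3. For compound 3 the expected value is 50000 nM, with an estimated range from 20000 nM to 120000 nM.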

Compound 3, half-maximal effective concentration: > 37900 nM
Compound 3: only a limit was reported; the forecaster's own chance of this, stated with the estimate: 50%; the middle value lies beyond the limit too.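

In this assay compound 3 gives > 37900 nM, a limit of the assay and not a number. Compound 2 likewise stands at a limit, > 34400 nM. Within the data shown here, no step to compound 3 can be read, either from compound 2 or from compound 1. The compounds shown leave open whether methyl in place of hydrogen on an aromatic nitrogen shifts the read-out at all.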